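Swapping Methyl for Chloro in a Growth Inhibition Series

This account rests on a few compounds, and the source may have more. Where it says the series, first, only, none or still open, it means among the compounds named here.

Three compounds sharing one core were tested in an ADME assay on A549 cells (Homo sapiens) for inhibition, read by MTT assay, with a stated time of 48 h; a lower number here means a stronger inhibitor of growth, a higher number a weaker inhibitor of growth. Compound 1 `Cc1ccc(OCc2cn(Cc3ccc([N+](=O)[O-])cc3)nn2)cc1` reached only the limit of the assay, giving > 100 ug/mL and no number. Compound 2 `Cc1ccc(OCc2cn(Cc3ccc(Cl)cc3)nn2)cc1` likewise stopped at the assay limit, > 100 ug/mL. Compound 3 `Cc1ccc(OCc2cn(Cc3cccc(Cl)c3)nn2)cc1` also gave only the limit, > 100 ug/mL. Compound 2 therefore stands at the edge of what this assay reports, alongside the other two, and none of the three can be placed in order against another. The steps a step that the two limits leave unreadable from compound 1 to compound 2 and a step that the two limits leave unreadable from compound 2 to compound 3 give no guidance, because of the limit of > 100 ug/mL in this assay, at which 3 of the 3 values shown sit.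

Compound 4 `Clc1ccc(Cn2cc(COc3ccc(Cl)cc3)nn2)cc1` differs from compound 2 by chloro in place of methyl on an aromatic carbon. Neither measured step bears on this change in a readable way, as both are hidden behind the same limit. With nothing in the data pointing toward stronger growth inhibition, compound 4 is expected to stay near the limit, an expected step that the limit leaves unreadable from compound 2 to compound 4. The estimate for compound 4 in this assay is 150 ug/mL, within a range from 60 ug/mL to 400 ug/mL.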

Compound 4, concentration for 50% growth inhibition: > 100 ug/mL
Compound 4 gave a limit, no number; the forecaster's own chance of this, stated with the estimate: 85%; the middle value does not contradict the limit.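

Compound 4 also stopped at a limit of the assay, > 100 ug/mL, and gave no number. No step can be read between compound 2 and compound 4, because the comparison rests on limits alone: the limit of > 100 ug/mL in this assay, at which 4 of the 4 values shown sit.

The compounds shown leave open whether any change to the shared core would bring a measurable number in this assay.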